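The compounds below may be only part of what the source reports. "The series", "measured", "known", "first", "only" and "open" are said of these compounds alone.

Working notes on the series, read in a functional assay on MCF7 cells (Homo sapiens) for cytotoxicity, read by MTT assay, with a stated time of 72 h; a lower number here means a stronger inhibitor, a higher number a weaker inhibitor. Compound 1 (`CN(C)CCCCCn1c2c(c3ccccc31)C(=O)c1c[n+]([O-])c3ccccc3c1C2=O`) gives 200 nM and compound 2 (`O=C1c2c[n+]([O-])c3ccccc3c2C(=O)c2c1c1ccccc1n2Cc1cn([C@@H]2C[C@H](O)[C@@H](CO)O2)nn1`) gives 110 nM. These two numbers lie within the usual scatter of each other, so compound 2 stands level with compound 1 on the data so far.

Compound 3 (`O=C1c2c[n+]([O-])c3ccccc3c2C(=O)c2c1c1ccccc1n2Cc1cn(C[C@H](O)CO)nn1`) has not yet been measured. It departs from compound 2 as follows: 2,3-dihydroxypropyl in place of 4-hydroxy-5-(hydroxymethyl)oxolan-2-yl on an aromatic nitrogen. In words, 2,3-dihydroxypropyl stands in place of 4-hydroxy-5-(hydroxymethyl)oxolan-2-yl on an aromatic nitrogen, and the shared core is kept.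

Within the data shown here, no measured pair shows this change, so there is no direct step to go on. Among the measured compounds shown here, the only guide is that compound 1 at 200 nM and compound 2 at 110 nM fall within the scatter of each other. On that thin basis, a large change is not expected in this assay. The expected outcome is a 1.4-fold higher number from compound 2 to compound 3 (0.13 log units; within the scatter), an estimated step that stays within the scatter, with no firm direction. The estimate for compound 3 is 150 nM, with an expected range of 60 nM to 400 nM.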

Compound 3, half-maximal inhibitory concentration: > 1000 nM
Compound 3 ended at the assay's limit (the forecaster's own chance of this, stated with the estimate: 3%); middle value at least 6.6-fold (0.82 log units) from the limit.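

In this assay compound 3 reads > 1000 nM, which is a limit of the assay and not a number: the limit of > 1000 nM in this assay, at which 1 of the 3 values shown sits.

With 2,3-dihydroxypropyl in place of 4-hydroxy-5-(hydroxymethyl)oxolan-2-yl on an aromatic nitrogen, the series shows an at least 9.0-fold higher number from compound 2 to compound 3 (0.95 log units; beyond the scatter), so this position responds to the change even though the count of hydrogen-bond donors stays the same and the ring of the leaving group is gone. The wider exchange of 1-(2,3-dihydroxypropyl)-1H-1,2,3-triazol-4-yl for 4-(dimethylamino)butyl gives an at least 5.0-fold higher number from compound 1 to compound 3 (0.69 log units; beyond the scatter); the two earlier compounds stood level and gave no sign that the group carried on the shared core could move the reading this far.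

On these data alone, the true size of both steps stays open, since each has only a lower bound. Also open, as far as these compounds go, is whether the ring of the leaving group or the particular placing of its hydroxyl groups is what counts here, a question that a simple 2-hydroxyethyl group, a cyclopentyl ring without hydroxyl groups, or a chain ending in an amine or a carboxylic acid on the same aromatic nitrogen would help to settle.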